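Acyclic and fused-ring analogues: acid to methylamide step

A few compounds are considered here, and "the series" means these few. Any claim that something is new, unique, unknown or untested is made for them only; others in the source may bear on it.

Measured compounds and their maximal responses in a functional assay on YAC-1 cells (Mus musculus); a lower number here means a smaller maximal response, a higher number a larger maximal response:
compound 1, `C=CCn1c(=O)n([C@@H]2O[C@H](CO)[C@H]3OC(C)(CCC(=O)O)O[C@H]32)c2nc(N)nc(O)c21`, gives 0%
compound 2, `CCCn1c(=O)n(C2C=CC(CO)O2)c2nc(N)nc(O)c21`, gives 102%
compound 3, `Nc1nc(O)c2nc(S)n(COCCO)c2n1`, gives 26%

Compound 1 stands lowest of the three numbers in this assay. Its nearest neighbour is compound 3, whose value lies higher by a margin beyond the usual scatter. Compound 2 lies furthest away, far above compound 1 and also well beyond the scatter. The three measured compounds differ from one another in several places at once, so no single-change step between measured compounds is available for this assay, and no cause for the spread can be read from the numbers.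

Compound 4, `C=CCn1c(=O)n([C@@H]2O[C@H](CO)[C@H]3OC(C)(CCC(=O)NC)O[C@H]32)c2nc(N)nc(O)c21`, is the next structure for measurement in this assay. It keeps the core of compound 1 and changes one place: methylamino in place of hydroxy on a carbonyl carbon. Nothing measured here tells how this change behaves, so the expectation rests on compound 1 alone. The step from a number 10 percentage points higher from compound 1 to compound 4 (within the scatter) is expected to be small, at most just beyond the scatter and pointing upward, as the carboxylic acid of compound 1 sits at zero and a number cannot fall below that. For compound 4 the maximal response in this assay is estimated at 10%, with a range from 0% to 35%.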

Compound 4, largest response reached (reported as maximal response), in percent of the reference or control that the assay uses: 0%
Beside the measured number, compound 4's estimate is 10 percentage points above it; the range from low to high includes it.
By their numbers in this assay, from the lowest: compounds 1 and 4 (each within the scatter of the next); then compound 3; then compound 2.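

In this assay the series now has its first single-change step, no change at the digits printed from compound 1 to compound 4 (within the scatter), with methylamino in place of hydroxy on a carbonyl carbon. Until now, the reading of compound 1 stood alone and could not be tied to any one group; this step shows that the carboxy end of the chain can be exchanged for methylcarbamoyl without moving the number, as compound 4 gives 0% in this assay. Both compounds sit at the bottom of the scale, so the step cannot show whether this exchange would matter on a compound with a higher response. No measurement at hand bears on why the number stays where it stands.

From the compounds shown here alone, it remains open whether a methyl ester, a dimethylamino amide or a primary alcohol at the end of the same chain would also leave the response unchanged. Going by these compounds, it also remains open whether a shorter or longer chain carrying the carboxylic acid, or a propyl group in place of the allyl group on the core of compound 1, would lift the response.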